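A few compounds are considered here, and "the series" means these few. Any claim that something is new, unique, unknown or untested is made for them only; others in the source may bear on it.

In a functional assay on HCT-116 cells (Homo sapiens) for antiproliferative activity (a lower number here means a stronger inhibitor, a higher number a weaker inhibitor), compound 1 `c1ccc2c(-c3cnc4[nH]nc(-c5nc6ccccc6[nH]5)c4c3)cncc2c1` gives 550 nM, the lower of the two numbers in hand. Compound 2 `Cc1cccc2[nH]c(-c3n[nH]c4ncc(-c5cncc6ccccc56)cc34)nc12` gives 1640 nM. Going by the values given here, the only measured change, a 3.0-fold higher number from compound 1 to compound 2 (0.47 log units; beyond the scatter), put a small group onto an aromatic carbon of the shared core. Compound 3 `CN1CCN(c2ccc3[nH]c(-c4n[nH]c5ncc(-c6cncc7ccccc67)cc45)nc3c2)CC1` carries a bulkier change of the same kind: 4-methylpiperazin-1-yl in place of hydrogen on an aromatic carbon. With just that one step as a guide, a modest weakening is expected for compound 3, namely a 1.6-fold higher number from compound 1 to compound 3 (0.21 log units; within the scatter), though the range is wide. Compound 3 is therefore estimated at 900 nM, plausibly anywhere between 250 nM and 3500 nM.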

Compound 3, half-maximal inhibitory concentration: 360 nM
Beside the measured number, compound 3's estimate is 2.5-fold (0.40 log units) above it; measured number inside the range.
By their numbers in this assay, from the lowest: compounds 3 and 1 (each within the scatter of the next); then compound 2.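

In this assay putting 4-methylpiperazin-1-yl on this aromatic carbon gives a 1.5-fold lower number from compound 1 to compound 3 (0.18 log units; within the scatter) and so shows that this carbon of the shared core can carry a ring of this size without a loss beyond the scatter. The methyl of compound 2 sits on a different carbon of that ring, so its step says little about this position. Nothing available explains the result. On these data alone, it remains open whether 4-methylpiperazin-1-yl would behave the same way on the methyl-bearing carbon of compound 2, and whether a morpholine ring or a carboxylic acid would be accepted at the position used in compound 3.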